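Disulfide series: half-life expectation for compound 3

The source may report more compounds than this note shows. Statements on the series, on what has been measured and on what is new or still open speak of the compounds shown alone.

Measured compounds:
Compound 1, `Cc1cn([C@H]2C[C@H](SSc3ccccc3[N+](=O)[O-])[C@@H](CO)O2)c(=O)[nH]c1=O`: in a physicochemical assay for metabolic stability, in the presence of a further agent that is not named here (on this read-out lower numbers stand for a shorter-lived compound and higher numbers for a longer-lived compound), compound 1 gives < 0.167 h, which is a limit of the assay and not a number.
Compound 2, `CCCCCCSS[C@H]1C[C@H](n2cc(C)c(=O)[nH]c2=O)O[C@@H]1CO`: in this assay compound 2 gives < 8 h, again a limit of the assay.

Compound 1 therefore has no measured number in this assay, only the limit given in the limit of < 0.167 h in this assay, at which 1 of the 2 values shown sits; the second value shown is also a limit, (the limit of < 8 h in this assay, at which 1 of the 2 values shown sits). Compound 3, `Cc1cn([C@H]2C[C@H](SSCCN)[C@@H](CO)O2)c(=O)[nH]c1=O`, differs from compound 1 by 2-aminoethyl in place of 2-nitrophenyl on a sulfur. Within the data shown here, the one measured step that resembles this change is a step that the two limits leave unreadable from compound 1 to compound 2, but both of its ends are limits, so neither its size nor its direction can be read, and nothing beyond that step bears on the change. For compound 3 the estimated step of an at least 5.9-fold higher number from compound 1 to compound 3 (0.77 log units; beyond the scatter) is accordingly wide and its direction uncertain. In this assay compound 3 is expected to give 1 h, with a range from 0.1 h to 8 h.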

Compound 3, half-life: < 8 h
Compound 3: no number, only a limit (the forecaster's own chance of this, stated with the estimate: 40%); the middle value is on the limit's open side.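

In this assay compound 3 gives < 8 h which is a limit of the assay and not a number. Among these compounds, compound 1 and compound 2 also stand at limits, so no step among compound 1, compound 2 and compound 3 can be read. On these data alone, the actual half-lives of all three, and their order, remain open.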